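This account rests on a few compounds, and the source may have more. Where it says the series, first, only, none or still open, it means among the compounds named here.

Compound 2 `Cc1ccc(S(=O)(=O)N(Cc2nc3ccccc3[nH]2)c2ccccc2)cc1` and compound 1 `Cc1ccc(S(=O)(=O)N(Cc2nc3ccccc3[nH]2)c2ccc(F)cc2)cc1` share one core; compound 3 `COc1cc(N(Cc2nc3ccccc3[nH]2)C(=O)c2ccccc2)cc(OC)c1OC` and compound 4 `COc1cc(N(Cc2nc3ccccc3[nH]2)C(=O)c2ccc(F)cc2)cc(OC)c1OC` share another, and the difference between the two cores is not broken down here. In a functional assay on MGC-803 cells (Homo sapiens) for inhibition, read by MTT assay, with a stated time of 48 h (a lower number here means a stronger inhibitor, a higher number a weaker inhibitor), compound 2 gives 45200 nM. In this assay compound 1 gives 34600 nM. The change between them is fluoro in place of hydrogen on an aromatic carbon and it produced a step of a 1.3-fold lower number from compound 2 to compound 1 (0.12 log units; within the scatter). Compound 3 reaches only a limit of this assay, > 50000 nM, so its standing in the series rests on (the limit of > 50000 nM in this assay, at which 1 of the 3 values shown sits). The change from compound 3 to compound 4 is fluoro in place of hydrogen on an aromatic carbon, the same kind of change as from compound 2 to compound 1, at a place described in the same words. Given that the earlier step stayed within the scatter, the step from compound 3 to compound 4 is expected to be a step that the limit leaves unreadable from compound 3 to compound 4. Because compound 3 sits at the limit of > 50000 nM in this assay, at which 1 of the 3 values shown sits, compound 4 is expected most often to return a limit as well rather than a number. Compound 4 is estimated at 60000 nM in this assay, with a likely range from 30000 nM to 150000 nM.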

Compound 4, half-maximal inhibitory concentration: 23600 nM
Compound 4: the middle estimate sits 2.5-fold (0.41 log units) above what was measured; measured number below the stated range.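

In this assay, fluoro in place of hydrogen on the aromatic carbon of the benzoyl group gives an at least 2.1-fold lower number from compound 3 to compound 4 (0.32 log units; beyond the scatter). As far as these compounds go, compound 3 stands at a limit of the assay and not at a number, so this step is a minimum and its true size stays unknown: the limit of > 50000 nM in this assay, at which 1 of the 4 values shown sits. The change lies beyond the scatter on this core and within it on the other, yet this does not show that the change carries over with the same size, nor that its size depends on the core: the same change on two cores in this assay, a 1.3-fold lower number (0.12 log units; within the scatter) from compound 2 to compound 1 and an at least 2.1-fold lower number (0.32 log units; beyond the scatter) from compound 3 to compound 4; the limit leaves it open whether they differ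

The compounds shown leave open whether chloro or an amine in the same place, para to a large group, would follow fluoro on either core. They also leave the difference between the two cores unresolved, as no pair shown differs there in one place alone.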